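A few compounds are considered here, and "the series" means these few. Any claim that something is new, unique, unknown or untested is made for them only; others in the source may bear on it.

Compound 1, `CC1(C)C(=O)N(c2ccc(SC(F)(F)F)cc2)C(=O)N1Cc1ccncc1`: < 0.02 ug/mL
Compound 2, `CC1(C)C(=O)N(c2ccc(SC(F)(F)F)cc2)C(=O)N1Cc1ccnc(N2CCCCC2)c1`: < 0.024 ug/mL
Compound 3, `COc1ccc(CNc2cc(CN3C(=O)N(c4ccc(SC(F)(F)F)cc4)C(=O)C3(C)C)ccn2)cc1`: < 0.027 ug/mL

In a physicochemical assay for solubility, read by nephelometry (on this read-out higher numbers stand for higher solubility and lower numbers for lower solubility), compound 1 gives < 0.02 ug/mL, which is a limit of the assay rather than a measured number. Compound 2 gives < 0.024 ug/mL, again a limit. Compound 3 gives < 0.027 ug/mL, also a limit. All three values shown are such limits (the limit of < 0.02 ug/mL in this assay, at which 1 of the 3 values shown sits, (the limit of < 0.024 ug/mL in this assay, at which 1 of the 3 values shown sits), (the limit of < 0.027 ug/mL in this assay, at which 1 of the 3 values shown sits)), so where compound 1 stands among them cannot be read, and the steps a step that the two limits leave unreadable from compound 1 to compound 2 and a step that the two limits leave unreadable from compound 1 to compound 3 give no size.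

Compound 4, `CCc1cc(CN2C(=O)N(c3ccc(SC(F)(F)F)cc3)C(=O)C2(C)C)ccn1`, differs from compound 1 by ethyl in place of hydrogen on an aromatic carbon. Among the measured compounds shown here, no measured step bears directly on this change, and the two steps that start from compound 1 both end at a limit, so they say nothing about its size. For the measured compounds named here, with every value so far a limit, compound 4 is expected to stay there as well. The expected step from compound 1 is a number no lower from compound 1 to compound 4 (the limit leaves the size open), none beyond the scatter. The estimate for compound 4 is therefore 0.02 ug/mL, in the range from 0.005 ug/mL to 0.1 ug/mL.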

Compound 4, solubility: < 0.022 ug/mL
Compound 4: a limit, no number; the forecaster's own chance of this, stated with the estimate: 85%; the middle value is on the limit's open side.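

In this assay compound 4 gives < 0.022 ug/mL, which is a limit of the assay and not a number. Among the compounds shown here, compound 1, compound 2 and compound 3 also stand at limits, so no step from any of them to compound 4 can be read. From the compounds shown here alone, the actual solubility of all four compounds stays open, as does any effect of the ethyl group on it.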